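A few compounds are considered here, and "the series" means these few. Any claim that something is new, unique, unknown or untested is made for them only; others in the source may bear on it.

The series centres on coumarin-derived hydrazones examined in a functional assay on CCRF-CEM cells (Homo sapiens) for antiproliferative activity, read by fluorescence and resazurin assay, with a stated time of 48 h; a lower number here means a stronger inhibitor, a higher number a weaker inhibitor. Compound 1 `CCOc1ccc2nc(Cl)c(/C=N/NC(=O)c3cc4ccc(O)cc4oc3=O)cc2c1` gives 17100 nM in this assay, compound 3 `CCOc1ccc2nc(Cl)c(/C=N/NC(=O)c3cc4cc(Br)ccc4oc3=O)cc2c1` gives 12900 nM, and compound 2 `O=C(N/N=C/c1ccncc1)c1cc2cc(Br)ccc2oc1=O` gives 6340 nM. Compound 2 therefore stands at the lowest number of the three; its gap to compound 3 and its larger gap to compound 1 both lie beyond the usual scatter of such measurements, so among these three it is the strongest inhibitor.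

From compound 2 the account turns to compound 4 `O=C(N/N=C/c1ccncc1)c1cc2ccccc2oc1=O`, which is not yet measured. The change is hydrogen in place of bromo on an aromatic carbon. Among the compounds with values here, no step between two measured compounds shows what this particular change does in this assay, so the expectation rests on compound 2 alone.

Compound 4 is expected to remain in the same broad region as compound 2, with a modest shift toward a higher number, the step from compound 2 to compound 4 estimated at a 1.6-fold higher number from compound 2 to compound 4 (0.20 log units; within the scatter). For compound 4 the expected value in this assay is therefore 10000 nM, within a range from 4000 nM to 25000 nM.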

Compound 4, half-maximal inhibitory concentration: 3110 nM
Estimate against measurement, compound 4: 3.2-fold (0.51 log units) above, and the stated range ends above it.
By their numbers in this assay, from the lowest: compound 4; then compound 2; then compounds 3 and 1 (each within the scatter of the next).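

In this assay, within the data shown here, the bromo group on this aromatic carbon, meta to a fused ring and para to a fused ring, proves dispensable: replacing it with hydrogen gives a 2.0-fold lower number from compound 2 to compound 4 (0.31 log units; beyond the scatter) and this step is the first to isolate a single change. The earlier compounds shown here could not show this, since compound 1, compound 2 and compound 3 differ in more than one place, and the pair now shows that, with the rest of the structure held constant, the lower number belongs to the compound without bromo. No measurement among the data shown accounts for this shift.

As far as these compounds go, the finding rests on a single pair, so it remains open whether a chloro, methoxy or amino group on this same aromatic carbon would fall nearer to hydrogen or to bromo. Among these compounds, it is also open whether hydrogen in place of bromo would produce a similar step when the other end of the molecule is the one carried by compound 3, rather than the one shared by compound 2 and compound 4.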